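The source may hold more compounds than are shown below. What is called first, only, known or untested is meant among the compounds shown, and "the series" means these compounds.

Measured so far in a functional assay on MCF7 cells (Homo sapiens) for cytotoxicity, read by MTT assay, with a stated time of 2 days, tested at 0.1 uM; a higher number here means a weaker effect of the compound at the concentration tested, a lower number a stronger effect:
- compound 1 `CC(=O)c1cc(-c2ccccc2)cc2cc(-c3ccccc3)[nH]c12`: 99.3%
- compound 2 `COc1ccc(-c2cc(C(C)=O)c3[nH]c(-c4ccccc4)cc3c2)cc1`: 99.2%

Going by the values given here, compound 1 and compound 2 sit together within the scatter of this assay; the single measured step, a number 0.1 percentage points lower from compound 1 to compound 2 (within the scatter), is too small to read as a change. Among the compounds with values here, with only two numbers, and no separation between them, compound 1 stands nowhere in particular: both compounds show essentially no effect at the concentration tested.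

The next compound is compound 3 `CC(=O)c1cc(-c2ccccc2)cc2cc(-c3ccc(F)cc3)[nH]c12`. It differs from compound 1 by fluoro in place of hydrogen on an aromatic carbon.

Within the data shown here, no measured step concerns the phenyl that carries this change; the one step on record, a number 0.1 percentage points lower from compound 1 to compound 2 (within the scatter), concerns a methoxy on the other phenyl and lay within the scatter. Among the measured compounds shown here, that step is the only guide, and it suggests that a small substituent on a phenyl of this core does not move this assay. The expectation for compound 3 is therefore a step of about a number 1.3 percentage points lower from compound 1 to compound 3 (within the scatter), none beyond the scatter. Compound 3 is estimated at 98%, within a range from 88% to 104%.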

Compound 3, a percentage reported as activity, at one concentration (the size of the read-out at that concentration, not a potency): 98.5%
Estimate against measurement, compound 3: 0.5 percentage points below; the range from low to high includes it.
By their numbers in this assay, from the lowest: compounds 3, 2 and 1 (each within the scatter of the next).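

Working note on the phenyl that carries the change: in this assay, going from phenyl to 4-fluorophenyl gives a number 0.8 percentage points lower from compound 1 to compound 3 (within the scatter). Going by these compounds alone, this adds a first reading on this phenyl, where the fluoro leaves the read-out where it was, and the methoxy on the other phenyl gave a number 0.1 percentage points lower from compound 1 to compound 2 (within the scatter). Each phenyl has now taken one substituent without a step beyond the scatter, though that rests on one fluoro and one methoxy, and no measurement on hand bears on why the read-out stays put.

Still open, on these data alone, is whether any group on these phenyls can move this read-out at all, for instance an amine or a carboxylic acid in place of the fluoro, or whether a change elsewhere on the shared core, such as a longer chain in place of the acetyl group, would do so. With all three compounds showing essentially no effect at this single concentration, these numbers also cannot tell whether the fluoro would matter at a concentration where the series does show an effect.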